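Notes on a shared-core series: compound 4 pending measurement

This account rests on a few compounds, and the source may have more. Where it says the series, first, only, none or still open, it means among the compounds named here.

Measured so far:
compound 1 `Nc1[nH]nc2nnc(-c3ccccn3)c(-c3ccccn3)c12` — > 100000 nM (a limit)
compound 2 `Nc1nn(COCCO)c2nnc(-c3ccccc3)c(-c3ccccc3)c12` — > 100000 nM (a limit)
compound 3 `Nc1[nH]nc2nnc(-c3ccc(C(F)(F)F)cc3)c(-c3ccc(C(F)(F)F)cc3)c12` — > 100000 nM (a limit)

In a functional assay on HeLa cells (Homo sapiens) for cytotoxicity (a higher number here means a weaker inhibitor, a lower number a stronger inhibitor), compound 1 gives > 100000 nM, which is a limit of the assay and not a measured number. Compound 2 gives > 100000 nM in this assay, again only a limit. Compound 3 gives > 100000 nM, also a limit. Among the measured compounds shown here, compound 2 thus stands at the same limit as every other value shown; all three measured compounds sit at the limit of > 100000 nM in this assay, at which 3 of the 3 values shown sit, so no compound in the set has a numerical reading at all, and no step between measured compounds can be drawn.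

Compound 4 `Nc1nn(Cc2ccccc2)c2nnc(-c3ccccc3)c(-c3ccccc3)c12` is to be measured in this assay. Against compound 2 the change is phenyl in place of 2-hydroxyethoxy on a saturated chain carbon bound to an aromatic nitrogen; cut one bond further out it reads as (2-hydroxyethoxy)methyl to benzyl. Nothing measured in the series speaks for a shift in either direction from this exchange. The step that the limit leaves unreadable from compound 2 to compound 4 is therefore expected to lie within the scatter, with no gain in inhibition beyond it. Compound 4 is estimated at 150000 nM, between 30000 nM and 600000 nM, and most probably the assay will again report only a limit.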

Compound 4, half-maximal inhibitory concentration: > 100000 nM
Compound 4: no number, only a limit (the forecaster's own chance of this, stated with the estimate: 80%); the middle value does not contradict the limit.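

Compound 2 and compound 4 both give only a limit in this assay, so no step between them can be read: the limit of > 100000 nM in this assay, at which 4 of the 4 values shown sit.

The compounds shown leave open whether any compound on the shared core gives a numerical reading in this assay and what the change from (2-hydroxyethoxy)methyl to benzyl does to such a reading.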